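Swapping the Carbonyl Substituent of Compound 1: An Estimate

This account rests on a few compounds, and the source may have more. Where it says the series, first, only, none or still open, it means among the compounds named here.

The measured compounds and their values in a functional assay on HEK293 cells for agonist activity at lutropin-choriogonadotropic hormone receptor (Homo sapiens), read by cAMP accumulation; on this read-out lower numbers stand for smaller maximal responses and higher numbers for larger maximal responses:
compound 1 `COc1cccc(-c2nc(SC)nc3sc(C(=O)NCC#N)c(N)c23)c1` gives 20.3%;
compound 2 `CSc1nc(-c2cccc(F)c2)c2c(N)c(C(=O)NC(C)(C)C)sc2n1` gives 51.1%;
compound 3 `COc1cccc(-c2nc(SC)nc3sc(C(=O)NC(C)(C)C)c(N)c23)c1F` gives 46.3%.

Compound 1 stands lowest of the three in this assay, and its gaps to compound 3 and to compound 2 both lie beyond the scatter. Among the compounds with values here, the only step with one change among the measured compounds is a number 4.8 percentage points lower from compound 2 to compound 3 (within the scatter), a change on the aromatic ring, within the scatter.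

Compound 4 `COc1cccc(-c2nc(SC)nc3sc(C(=O)OC(C)(C)C)c(N)c23)c1` is not yet measured. It differs from compound 1 at the carbonyl carbon: tert-butoxy in place of (cyanomethyl)amino on a carbonyl carbon. Within the data shown here, no measured step touches this position, so the step from compound 2 to compound 3 does not bear on it. What the data do show is that compounds 2 and 3, which carry tert-butyl on the carbonyl side, sit well above compound 1, which carries cyanomethyl there, though they also differ from compound 1 on the aromatic ring and keep the hydrogen-bond donor that compound 4 loses.

On this basis compound 4 is expected to rise moderately, with an estimated step of a number 14.7 percentage points higher from compound 1 to compound 4 (beyond the scatter). The estimate for compound 4 in this assay is 35%, between 15% and 60%.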

Compound 4, largest response reached (reported as efficacy), in percent of the reference or control that the assay uses: 23.8%
The estimate for compound 4 lay 11.2 percentage points above the measured number; the range from low to high includes it.
By their numbers in this assay, from the lowest: compounds 1 and 4 (each within the scatter of the next); then compounds 3 and 2 (each within the scatter of the next).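

In this assay, within the data shown here, the exchange of (cyanomethyl)amino for tert-butoxy on the carbonyl carbon gives a number 3.5 percentage points higher from compound 1 to compound 4 (within the scatter) and is the first reading of this position with the rest of the molecule held the same. The change removes the hydrogen-bond donor and the nitrile of compound 1 and brings in the branched tert-butoxy group, yet compound 1 and compound 4 cannot be told apart on this read-out, so this position tolerates this particular exchange without a step beyond the scatter. Nothing available bears on why these two groups read alike.

No pair shown differs only by tert-butylamino against (cyanomethyl)amino or tert-butoxy on this carbonyl carbon, so what tert-butylamino itself contributes on the core of compound 1 stays open. From the compounds shown here alone, how a carboxylic acid, a methylamino group or a longer alkoxy chain on the same carbonyl carbon would read in this assay also remains open.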